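This account rests on a few compounds, and the source may have more. Where it says the series, first, only, none or still open, it means among the compounds named here.

Compound 1 `NNC(=O)CCc1ccncc1-c1ccc2ccccc2c1` stands in a functional assay on HCT-116 cells (Homo sapiens) for inhibition, read by MTT assay, with a stated time of 72 h (a higher number here means a weaker inhibitor of growth, a lower number a stronger inhibitor of growth), only at a limit: compound 1 gives > 30000 nM, which is not a number, as the limit of > 30000 nM in this assay, at which 1 of the 2 values shown sits, shows. Compound 2 `Cn1ccc2cc(-c3cnccc3/C=C/C(=O)O)ccc21` in this assay gives 7260 nM. The unmeasured compound 3 `O=C(/C=C/c1ccncc1-c1ccc2ccccc2c1)NC1CC1` differs from compound 1 in one place (2-(cyclopropylcarbamoyl)ethenyl in place of 2-(aminocarbamoyl)ethyl on an aromatic carbon). Among the measured compounds shown here, no measured pair in this assay carries this change, so its size is uncertain; a step toward stronger growth inhibition beyond the scatter is expected, since compound 2 gives 7260 nM in the same assay. Compound 3 is estimated at 5000 nM, within 1000 nM to 30000 nM. That expectation means a step of an at least 6.0-fold lower number from compound 1 to compound 3 (0.77 log units; beyond the scatter).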

Compound 3, concentration for 50% growth inhibition: 6180 nM
Compound 3: the middle estimate sits 1.2-fold (0.09 log units) below what was measured, and the stated range covers the measured number.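

On the shared core, at the aromatic carbon opposite the ring nitrogen, placing 2-(cyclopropylcarbamoyl)ethenyl where 2-(aminocarbamoyl)ethyl stood gives, in this assay, an at least 4.8-fold lower number from compound 1 to compound 3 (0.68 log units; beyond the scatter). Growth inhibition therefore responds to the group at this position. The true size of the step remains unknown because compound 1 stands at a limit, not a number: the limit of > 30000 nM in this assay, at which 1 of the 3 values shown sits.

This change alters both the chain's double bond and its cyclopropyl end, so the compounds shown cannot separate the two. On these data alone, whether a methyl amide or a longer chain would serve equally well remains open.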